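The source may hold more compounds than are shown below. What is called first, only, known or untested is meant among the compounds shown, and "the series" means these compounds.

Compound 1 `Cc1ccc2c(c1)N(S(=O)(=O)c1ccc(-c3cnc(C4CC4)o3)cc1)CCCO2` and compound 2 `Cc1ccc2c(c1)OCCCN2S(=O)(=O)c1ccc(-c2cnc(C3CC3)o2)cc1` are made of the same atoms joined differently; how their two cores differ is not broken down here. In a functional assay on PC-3 cells (Homo sapiens) for antiproliferative activity, read by MTT assay, with a stated time of 72 h (on this read-out higher numbers stand for weaker inhibition and lower numbers for stronger inhibition), compound 1 gives 41 nM, while compound 2 gives 241 nM, the highest number among the three measured compounds. Compound 3 `COc1ccc2c(c1)N(S(=O)(=O)c1ccc(-c3cnc(C4CC4)o3)cc1)CCCO2` is compound 1 with methoxy in place of methyl on an aromatic carbon. In this assay compound 3 gives 14 nM, so that single change brought a 2.9-fold lower number from compound 1 to compound 3 (0.47 log units; beyond the scatter). Compound 4 `COc1ccc2c(c1)OCCCN2S(=O)(=O)c1ccc(-c2cnc(C3CC3)o2)cc1` stands to compound 2 as compound 3 stands to compound 1: it carries methoxy in place of methyl on an aromatic carbon, the same change at the same place, now on the other core. Because the step of a 2.9-fold lower number from compound 1 to compound 3 (0.47 log units; beyond the scatter) came from exactly this change, the step expected from compound 2 to compound 4 is a 2.5-fold lower number from compound 2 to compound 4 (0.40 log units; beyond the scatter). That expectation is set a little smaller than the earlier step, one example on a different core being a thin base for a second. On that basis compound 4 is expected to give about 95 nM in this assay. The range for compound 4 is estimated to run from 40 nM to 220 nM.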

Compound 4, half-maximal inhibitory concentration: 271 nM
Estimate against measurement, compound 4: 2.9-fold (0.46 log units) below, and the stated range ends below it.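

In this assay, putting methoxy in place of methyl on the core of compound 2 gave a 1.1-fold higher number from compound 2 to compound 4 (0.05 log units; within the scatter), so the change that lowered the number on the core of compound 1 made no measurable difference here. The two steps do not agree, and the gap between them is larger than repeat measurements would explain: the same change on two cores in this assay, a 2.9-fold lower number (0.47 log units; beyond the scatter) from compound 1 to compound 3 and a 1.1-fold higher number (0.05 log units; within the scatter) from compound 2 to compound 4, 3.3-fold (0.52 log units) apart, beyond the scatter of two such steps. For the compounds shown here, this shows that, in this series, the effect of this swap cannot simply be carried from one core to the other, although it rests on only one pair of compounds per core and does not show why the two cores respond differently.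

The compounds shown leave open whether a longer chain such as ethoxy, or a hydroxyl, an amine or a chlorine atom on the same aromatic carbon, would also separate the two cores. They also leave open whether the same difference between the cores would appear in other cell lines.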